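A few compounds are considered here, and "the series" means these few. Any claim that something is new, unique, unknown or untested is made for them only; others in the source may bear on it.

Compound 1 `Cc1c(O)ccc2c1[C@H](Cn1cc(-c3ccc(Cl)cc3)nn1)[C@@]13CC(=O)[C@@](C)(CC[C@@H]21)C3` carries a free hydroxy group on the aromatic ring of its core. In a functional assay on A549 cells (Homo sapiens) for cytotoxicity, read by MTT assay, with a stated time of 4 days (on this read-out higher numbers stand for weaker inhibition and lower numbers for stronger inhibition), compound 1 gives > 20000 nM, which is a limit of the assay and not a number. Compound 2 `Cc1ccc(S(=O)(=O)Oc2ccc3c(c2C)[C@H](Cn2cc(-c4ccc(Cl)cc4)nn2)[C@@]24CC(=O)[C@@](C)(CC[C@@H]32)C4)cc1` differs from compound 1 by (4-methylphenyl)sulfonyl in place of hydrogen on an oxygen on an aromatic ring. In this assay compound 2 gives > 20000 nM, again a limit rather than a number. The step that the two limits leave unreadable from compound 1 to compound 2 cannot be read in size because both values sit at the limit of > 20000 nM in this assay, at which 2 of the 3 values shown sit. Compound 3 `C=C1C(=O)[C@]23C[C@@]1(O)CC[C@H]2c1ccc(O)c(C)c1[C@@H]3Cn1cc(-c2ccc(OC)cc2)nn1` is built on another core; the difference between the two cores is not broken down here. In this assay, going by the values given here, compound 3 gives 1250 nM, the only number among the three measured values. Compound 4 `C=C1C(=O)[C@]23C[C@@]1(O)CC[C@H]2c1ccc(OS(=O)(=O)c2ccc(C)cc2)c(C)c1[C@@H]3Cn1cc(-c2ccc(OC)cc2)nn1` has not yet been measured; it differs from compound 3 by (4-methylphenyl)sulfonyl in place of hydrogen on an oxygen on an aromatic ring, the same change that separates compound 1 from compound 2, made at the same place, an oxygen on an aromatic ring. Since the earlier step gave no readable size, any expectation for compound 4 rests on compound 3 alone, anchored to its value 1250 nM. Compound 4 is expected to give roughly 2500 nM, somewhere from 600 nM to 20000 nM, a step estimated at a 2.0-fold higher number from compound 3 to compound 4 (0.30 log units; within the scatter) that is held wide for want of a readable precedent.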

Compound 4, half-maximal inhibitory concentration: 1470 nM
Estimate against measurement, compound 4: 1.7-fold (0.23 log units) above, within the range that was stated.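

On the core of compound 3, going from hydroxy to ((4-methylphenyl)sulfonyl)oxy in this assay gives a 1.2-fold higher number from compound 3 to compound 4 (0.07 log units; within the scatter), so the two compounds cannot be told apart on this read-out. On the core of compound 1 the same change cannot be read, because compound 1 and compound 2 both sit at a limit of the assay and not at a number: the limit of > 20000 nM in this assay, at which 2 of the 4 values shown sit. With one readable step, the data show only what the change does on the core of compound 3; they do not show that it has the same size on both cores, or that it would stay as small on any further core.

The compounds shown leave open whether other groups on that oxygen, such as methyl, acetyl or a chain ending in an amine, would also leave the number within the scatter on the core of compound 3. They also leave open how a carboxylic acid carried there would read on either core.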